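Replacing a hydroxy group with methyl

The compounds below may be only part of what the source reports. "The series", "measured", "known", "first", "only" and "open" are said of these compounds alone.

Compound 1 `CCCCCCCCCCCCCCNC(=O)[C@H](CO)/N=C/c1ccccc1O`: 19000 nM
Compound 2 `CCCCCCCCCCCCCCNC(=O)[C@H](CO)/N=C/c1ccc(O)cc1`: 19300 nM

In a functional assay on cells (Homo sapiens) for cytotoxicity, read by MTT assay, with a stated time of 24 h (on this read-out lower numbers stand for stronger inhibition and higher numbers for weaker inhibition), compound 2 gives 19300 nM. That matches compound 1 within the usual scatter of repeated measurements, so neither can be ranked above the other.

Compound 3 `CCCCCCCCCCCCCCNC(=O)[C@H](CO)/N=C/c1ccc(C)cc1` keeps the shared core and the long chain and changes one group: methyl in place of hydroxy on an aromatic carbon. Put simply, this is methyl in place of hydroxy on an aromatic carbon, turning 4-hydroxyphenyl into 4-methylphenyl.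

Among the measured compounds shown here, only one measured step bears on this change: a 1.0-fold higher number from compound 1 to compound 2 (0.01 log units; within the scatter). That step lies within the scatter, but it is indirect evidence, since it moves the hydroxy group and does not replace it. Both measured compounds carry hydroxy, so the data contain no direct test of losing it. On this thin evidence, no change beyond the scatter is expected in this assay, and neither direction is favoured.

The expected step is a 1.0-fold higher number from compound 2 to compound 3 (0.02 log units; within the scatter). The estimated value for compound 3 is 20000 nM, with an expected range of 10000 nM to 40000 nM.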

Compound 3, half-maximal inhibitory concentration: 102000 nM
Compound 3: the middle estimate sits 5.1-fold (0.71 log units) below what was measured; the measured number lies above the stated range.
By their numbers in this assay, from the lowest: compounds 1 and 2 (each within the scatter of the next); then compound 3.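

In this assay, putting methyl where the hydroxy group stood on the aromatic ring gives a 5.3-fold higher number from compound 2 to compound 3 (0.72 log units; beyond the scatter), a weaker result on this read-out and a change beyond the scatter. So this position does respond to a change of group, which the earlier pair could not show, as both of those compounds carry hydroxy and their numbers lie within the scatter of each other. The comparison with the other hydroxy compound points the same way, with a 5.4-fold higher number from compound 1 to compound 3 (0.73 log units; beyond the scatter), so compound 3 stands apart from both, and nothing measured here explains why this swap weakens the result.

The compounds shown leave open whether the shift follows the loss of hydroxy or the arrival of methyl, and this single swap does both at once. They also leave open how an amine, a methoxy group or a plain hydrogen at the same place on the ring would read, which could help to separate those two possibilities.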